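Aryl amide variation in the nitrobenzofurazan ester series

The compounds below may be only part of what the source reports. "The series", "measured", "known", "first", "only" and "open" are said of these compounds alone.

Measured compounds:
compound 1 `O=C(CCC(=O)OCCCCCCSc1ccc([N+](=O)[O-])c2nonc12)Nc1ccccc1Cl`: 2950 nM
compound 2 `O=C(CCC(=O)OCCCCCCSc1ccc([N+](=O)[O-])c2nonc12)Nc1cccc(Cl)c1`: 1090 nM
compound 3 `Cc1ccc(NC(=O)CCC(=O)OCCCCCCSc2ccc([N+](=O)[O-])c3nonc23)cc1`: 2340 nM

In an ADME assay on HUVEC cells (Homo sapiens) for cytotoxicity, read by MTT assay, with a stated time of 72 h (on this read-out higher numbers stand for weaker inhibition and lower numbers for stronger inhibition), compound 2 gives the lowest of the three numbers; the steps run a 2.7-fold lower number from compound 1 to compound 2 (0.43 log units; beyond the scatter) and a 2.1-fold higher number from compound 2 to compound 3 (0.33 log units; beyond the scatter), while a 1.3-fold lower number from compound 1 to compound 3 (0.10 log units; within the scatter) stays within the scatter. Compound 4 `COc1ccc(NC(=O)CCC(=O)OCCCCCCSc2ccc([N+](=O)[O-])c3nonc23)cc1OC` is not yet measured. The change is 3,4-dimethoxyphenyl in place of 3-chlorophenyl on an amide-type nitrogen. For the measured compounds named here, no measured step touches a dimethoxyphenyl, so only the size of the aryl changes already seen bears on it: both steps leaving compound 2 are modest. A modest rise in the number is therefore expected for compound 4, estimated as a 1.8-fold higher number from compound 2 to compound 4 (0.26 log units; within the scatter). Compound 4 is expected at 2000 nM, with a range from 800 nM to 5000 nM.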

Compound 4, half-maximal inhibitory concentration: 870 nM
Compound 4: the middle estimate sits 2.3-fold (0.36 log units) above what was measured, and the stated range covers the measured number.
By their numbers in this assay, from the lowest: compounds 4 and 2 (each within the scatter of the next); then compounds 3 and 1 (each within the scatter of the next).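

In this assay, 3,4-dimethoxyphenyl on the amide-type nitrogen stays level with 3-chlorophenyl (a 1.3-fold lower number from compound 2 to compound 4 (0.10 log units; within the scatter)), so this position accepts a larger aryl with two hydrogen-bond acceptors and no chlorine. The same group separates from the other two aryls (a 2.7-fold lower number from compound 3 to compound 4 (0.43 log units; beyond the scatter); a 3.4-fold lower number from compound 1 to compound 4 (0.53 log units; beyond the scatter)), which places compound 4 with compound 2 in the lower pair. Nothing available gives a reason for these steps. Open, going by these compounds, is whether a single methoxy group would match the pair, and how an amine or a carboxylic acid on the aryl would read here.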